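A few compounds are considered here, and "the series" means these few. Any claim that something is new, unique, unknown or untested is made for them only; others in the source may bear on it.

Measured so far in a functional assay (strain AB) with Danio rerio as the target, read by microscopy, with a stated time of 1 h; a higher number here means that more compound is needed for the effect, a lower number that less compound is needed:
- Compound 1, `CCN1CCc2c(sc(NC(=S)Nc3ccc(Cl)cc3)c2C(N)=O)C1`: 6570 nM
- Compound 2, `CC(C)[N+]1(C)CCc2c(sc(NC(=O)Nc3ccc(Cl)cc3)c2C(N)=O)C1`: 960 nM

Of these two numbers, compound 2 has the lower, at 960 nM, and its gap to compound 1, at 6570 nM, lies beyond the scatter. These two compounds differ in more than one place, so their gap shows no effect of any single change.

Compound 3, `C[N+]1(CC2CCC2)CCc2c(sc(NC(=O)Nc3ccc(Cl)cc3)c2C(N)=O)C1`, has not yet been measured. It has cyclobutylmethyl in place of isopropyl on an amine nitrogen in a ring. Going by the values given here, no measured pair shows what such a swap does in this assay, so the estimate stays close to compound 2 at 960 nM. The expected change, a 1.1-fold lower number from compound 2 to compound 3 (0.05 log units; within the scatter), is small, with no shift beyond the scatter anticipated in either direction. For compound 3 the estimated value is 850 nM, with an expected range from 280 nM to 2600 nM.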

Compound 3, half-maximal effective concentration: 210 nM
Compound 3: middle estimate off by 4.0-fold (0.61 log units), on the high side; measured number outside the range, below it.
By their numbers in this assay, from the lowest: compound 3; then compound 2; then compound 1.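

In this assay, going by these compounds alone, the amine nitrogen in a ring now gives the first single change that can be read: cyclobutylmethyl in place of isopropyl brings a 4.6-fold lower number from compound 2 to compound 3 (0.66 log units; beyond the scatter), a shift beyond the usual scatter. This position is therefore not indifferent to the group it carries, and a group with a four-membered non-aromatic ring is accepted there with a lower number than isopropyl gives. Nothing available explains the shift.

Going by these compounds, whether the lower number goes with the ring itself or with the larger count of carbons stays open, as one step cannot separate the two. Cyclopropylmethyl, cyclopentylmethyl, benzyl or a straight butyl chain on the same nitrogen would bear on that question.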